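From Methyl to Chloro on the Shared Core

The compounds below may be only part of what the source reports. "The series", "measured", "known", "first", "only" and "open" are said of these compounds alone.

In a functional assay on NSCLC cells (Homo sapiens) for antiproliferative activity (on this read-out higher numbers stand for weaker inhibition of growth and lower numbers for stronger inhibition of growth), compound 1 `Cc1cn2c(/C=N/NC(=N)N)c(-c3ccncc3)nc2s1` gives 16600 nM, the lowest of three numbers, although compound 3 `N=C(N)N/N=C/c1c(-c2cc([N+](=O)[O-])c(Cl)cc2Cl)nc2sc(Cl)cn12` gives 22900 nM, within the scatter of it. Compound 2 `Cc1sc2nc(-c3ccncc3)c(/C=N/NC(=N)N)n2c1C` gives 38900 nM. Compound 4 `N=C(N)N/N=C/c1c(-c2ccncc2)nc2sc(Cl)cn12` has chloro in place of methyl on an aromatic carbon next to the ring sulfur: chloro in place of methyl on an aromatic carbon. Among the measured compounds shown here, the only measured step, a 2.3-fold higher number from compound 1 to compound 2 (0.37 log units; beyond the scatter), is modest and is a different change, methyl in place of hydrogen. Compound 3 carries chloro on that same carbon but also differs elsewhere, and it gives 22900 nM. No step beyond the scatter is therefore expected, the estimated change being a 1.1-fold higher number from compound 1 to compound 4 (0.04 log units; within the scatter). For compound 4 the expected value is 18000 nM, with an estimated range from 8000 nM to 40000 nM.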

Compound 4, concentration for 50% growth inhibition: 6760 nM
The estimate for compound 4 lay 2.7-fold (0.43 log units) above the measured number; the measured number lies below the stated range.
By their numbers in this assay, from the lowest: compound 4; then compounds 1, 3 and 2 (each within the scatter of the next, the first and the last beyond it).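

In this assay the exchange of methyl for chloro on this aromatic carbon next to the ring sulfur gives a 2.5-fold lower number from compound 1 to compound 4 (0.39 log units; beyond the scatter) and so shows that this position responds to the change. The step is modest, and its direction is opposite to that of the earlier, different change of methyl in place of hydrogen, a 2.3-fold higher number from compound 1 to compound 2 (0.37 log units; beyond the scatter) on the shared core. Nothing available gives a reason for the lower number with chloro. Going by these compounds, whether bromo or an amine on this carbon would move the number further remains open, as does whether the exchange of methyl for chloro gives a similar step in other compounds.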